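A few compounds are considered here, and "the series" means these few. Any claim that something is new, unique, unknown or untested is made for them only; others in the source may bear on it.

Compound 1 `CCn1cc(-c2ccc(Cl)cc2)c(=O)c2cc(F)c(N3CCNCC3)cc21`: 15400 nM
Compound 2 `O=c1c(-c2ccc(Cl)cc2)cn(C2CC2)c2cc(N3CCNCC3)c(F)cc12`: 9300 nM

In a functional assay on HeLa cells (Homo sapiens) for antiproliferative activity, read by MTT assay, with a stated time of 48 h (a higher number here means a weaker inhibitor, a lower number a stronger inhibitor), compound 2 gives 9300 nM and stands within the scatter of compound 1, so neither can be ranked over the other. Compound 3 `COc1cccc(-c2cn(C3CC3)c3cc(N4CCNCC4)c(F)cc3c2=O)c1` keeps the core of compound 2 and differs by 3-methoxyphenyl in place of 4-chlorophenyl on an aromatic carbon in one place: 3-methoxyphenyl in place of 4-chlorophenyl on an aromatic carbon. For the measured compounds named here, the only measured step, a 1.7-fold lower number from compound 1 to compound 2 (0.22 log units; within the scatter), lies within the scatter and concerns cyclopropyl in place of ethyl on an aromatic nitrogen, not this carbon. Going by the values given here, no measured step speaks directly to the new group, so in this assay no step beyond the scatter is expected in either direction, although the uncertainty stays wide. This expectation amounts to an estimated 1.1-fold higher number from compound 2 to compound 3 (0.03 log units; within the scatter) in this assay overall. The estimated value for compound 3 is 10000 nM with an expected range of 3500 nM to 30000 nM in this measurement.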

Compound 3, half-maximal inhibitory concentration: 920 nM
Estimate against measurement, compound 3: 11-fold (1.04 log units) above; measured number below the stated range.
By their numbers in this assay, from the lowest: compound 3; then compounds 2 and 1 (each within the scatter of the next).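

In this assay, the aromatic carbon bearing the aryl group gives the first step beyond the scatter among these compounds: replacing 4-chlorophenyl with 3-methoxyphenyl produces a 10-fold lower number from compound 2 to compound 3 (1.00 log units; beyond the scatter), whereas the change on the aromatic nitrogen gave only a 1.7-fold lower number from compound 1 to compound 2 (0.22 log units; within the scatter). The antiproliferative read-out is therefore sensitive to the aryl group at this position, at least with the cyclopropyl group on the ring nitrogen. Nothing available explains why this exchange lowers the number.

The exchange alters both the substituent and its place on the phenyl ring, so 3-chlorophenyl or 4-methoxyphenyl at this carbon would be needed to separate the two. Also open, as far as these compounds go, are whether a hydroxyl or an amine on that phenyl ring would serve as well, and whether the ethyl group on the ring nitrogen would give the same result with 3-methoxyphenyl.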